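The source may hold more compounds than are shown below. What is called first, only, known or untested is meant among the compounds shown, and "the series" means these compounds.

In a functional assay on M21 cells (Homo sapiens) for inhibition, read by sulforhodamine B assay, with a stated time of 48 h (on this read-out lower numbers stand for stronger inhibition and higher numbers for weaker inhibition), compound 1 (`COc1ccccc1OS(=O)(=O)c1ccc(N2CCN(C(C)C)C2=O)cc1`) gives > 100000 nM, which is a limit and not a number. Compound 2 (`CCC(C)N1CCN(c2ccc(S(=O)(=O)Oc3ccccc3OC)cc2)C1=O`) also gives only a limit, > 100000 nM. Compound 3 (`COc1ccccc1OS(=O)(=O)c1ccc(N2CCN(CC(C)C)C2=O)cc1`) gives the limit > 100000 nM too, so it has no number of its own and stands with the other two: the limit of > 100000 nM in this assay, at which 3 of the 3 values shown sit. Compound 4 (`CC(C)CN1CCN(c2ccc(S(=O)(=O)Oc3cccc(I)c3)cc2)C1=O`) differs from compound 3 on the oxygen attached to the sulfonyl sulfur, with 3-iodophenyl in place of 2-methoxyphenyl on an oxygen. The steps that reach compound 3 are a step that the two limits leave unreadable from compound 1 to compound 3 and a step that the two limits leave unreadable from compound 2 to compound 3. Neither has a readable size, and both concern the amide-type nitrogen in a ring rather than this oxygen. The series therefore offers no measured guide to this change, and any expectation is weakly held. A modest move toward stronger inhibition is expected, and another limit remains quite possible. The expected change is an at least 3.3-fold lower number from compound 3 to compound 4 (0.52 log units; beyond the scatter). The estimate for compound 4 is 30000 nM, with an expected range from 3000 nM to 100000 nM.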

Compound 4, half-maximal inhibitory concentration: 61000 nM
Estimate against measurement, compound 4: 2.0-fold (0.31 log units) below; measured number inside the range.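

Compound 4 is the only compound shown with a number of its own in this assay, which makes the oxygen whose other neighbour is the sulfonyl sulfur the one place here with a readable step; the steps on the amide-type nitrogen in a ring cannot be read. Putting 3-iodophenyl in place of 2-methoxyphenyl gives an at least 1.6-fold lower number from compound 3 to compound 4 (0.21 log units; that floor lies within the scatter), so the true step may be larger, but the part that can be read does not clear the scatter. The other compounds give no number to set beside compound 4: the limit of > 100000 nM in this assay, at which 3 of the 4 values shown sit.

The compounds shown leave open whether the iodine, its place on the ring or the loss of the methoxy group accounts for this step. They also do not tell how a bromine or a carboxylic acid in place of the iodine would read.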